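Swapping benzyl for cyclohexyl on a crown ether ester

The source may hold more compounds than are shown below. What is called first, only, known or untested is meant among the compounds shown, and "the series" means these compounds.

Compound 2 `O=C(CCCCCc1ccccc1)OCC1COCCOCCOCCOCCOCCO1` is an ester of a crown-ether alcohol carrying a 5-phenylpentyl chain. In a functional assay on SW1573 cells (Homo sapiens) for inhibition, read by sulforhodamine B assay, with a stated time of 48 h (a higher number here means a weaker inhibitor of growth, a lower number a stronger inhibitor of growth), compound 2 gives 78000 nM, the highest of the two numbers reported here. Its nearest neighbour is compound 1 `O=C(/C=C/c1ccccc1)OCC1COCCOCCOCCOCCOCCO1`, which gives 48000 nM; the step of a 1.6-fold higher number from compound 1 to compound 2 (0.21 log units; within the scatter) separates them. Compound 3 `O=C(CCCCC1CCCCC1)OCC1COCCOCCOCCOCCO1`, which carries a cyclohexyl group on a smaller crown ring, reaches only a limit in this assay, namely > 100000 nM. Compound 4 `O=C(CCCCC1CCCCC1)OCC1COCCOCCOCCOCCOCCO1` keeps the crown ring of compound 2 but makes the change (cyclohexyl in place of benzyl on a saturated chain carbon, four bonds along the chain from a carbonyl carbon). No measured step tests exactly this swap; the only step shown, from compound 1 to compound 2, lies within the scatter. The single hint from the cyclohexyl side is the limit of > 100000 nM in this assay, at which 1 of the 3 values shown sits. Compound 4 is therefore expected to sit near the edge of what this assay can report, with an estimate of 120000 nM and a range from 60000 nM to 300000 nM, because compound 3 with the same cyclohexyl group gives > 100000 nM. The expected step of a 1.5-fold higher number from compound 2 to compound 4 (0.19 log units; within the scatter) is a mild weakening, and a limit rather than a number is about as likely.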

Compound 4, concentration for 50% growth inhibition: 51000 nM
Compound 4: middle estimate off by 2.4-fold (0.37 log units), on the high side; the measured number lies below the stated range.
By their numbers in this assay, from the lowest: compounds 1, 4 and 2 (each within the scatter of the next). At a limit, above all of these: compound 3.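

In this assay there is a 1.5-fold lower number from compound 2 to compound 4 (0.18 log units; within the scatter) when cyclohexyl takes the place of benzyl on a saturated chain carbon, four bonds along the chain from a carbonyl carbon. An aromatic ring at the end of this chain is therefore not required for the growth inhibition seen with this crown ring. The comparison with the unsaturated ester agrees, with a 1.1-fold higher number from compound 1 to compound 4 (0.03 log units; within the scatter) when 4-cyclohexylbutyl takes the place of 2-phenylethenyl on a carbonyl carbon, so the cyclohexyl group alone does not carry a compound to the edge of the assay.

As far as these compounds go, compound 3, with the smaller crown ring, remains at a limit, and whether ring size alone accounts for it stays open: the limit of > 100000 nM in this assay, at which 1 of the 4 values shown sits. Also open, from the compounds shown here alone, is what an amine or a carboxylic acid at the end of the chain, or a longer chain, would do to these numbers.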